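The compounds below may be only part of what the source reports. "The series", "measured", "known", "first", "only" and "open" are said of these compounds alone.

Compound 1 `COc1cc2c(cc1OC)C(CC(=O)Nc1ccccc1)CC2`: 38.9%
Compound 2 `COc1cc2c(cc1OC)C(CC(=O)Nc1cccc(C)c1)CC2`: 38%

In a functional assay on the whole organism (strain Wistar) for inhibition, with Rattus norvegicus as the target, read by paw edema, with a stated time of 6 h, at a dose of 100 mg/kg (on this read-out higher numbers stand for more inhibition at the one dose given (going by the name of the read-out) and lower numbers for less inhibition), compound 2 gives 38% and compound 1 gives 38.9%; the two numbers sit within the scatter of each other, and the step of a number 0.9 percentage points lower from compound 1 to compound 2 (within the scatter) shows nothing beyond that. Compound 3 `COc1cc2c(cc1OC)C(CC(=O)Nc1cccnc1)CC2` differs from compound 2 by pyridin-3-yl in place of 3-methylphenyl on an amide-type nitrogen. Among the measured compounds shown here, the one measured step concerns the same amide-type nitrogen but a different exchange, so it offers only a loose guide; for compound 3 the expected step is a number 2 percentage points lower from compound 2 to compound 3 (within the scatter), none beyond the scatter. Compound 3 is estimated at 36%, in a range from 22% to 50%.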

Compound 3, a percentage reported as inhibition, in the whole organism at one dose (the size of the read-out at that dose, not a potency): 35.2%
The estimate for compound 3 lay 0.8 percentage points above the measured number; the range from low to high includes it.
By their numbers in this assay, from the lowest: compounds 3, 2 and 1 (each within the scatter of the next).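

Among the compounds shown here, putting pyridin-3-yl on the amide-type nitrogen brings a ring nitrogen into this position for the first time, and in this assay it gives a number 2.8 percentage points lower from compound 2 to compound 3 (within the scatter) and a number 3.7 percentage points lower from compound 1 to compound 3 (within the scatter) as well. The exchange of a carbon-only ring for this hetero-atom ring therefore does not separate the three compounds at the one dose given. Nothing available explains this result or bears on it.

From the compounds shown here alone, whether a non-aromatic group such as cyclohexyl on the amide-type nitrogen would move the number beyond the scatter stays open. So does the effect of a carboxylic acid or an amine on the aromatic ring.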